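Methoxy in Place of Chloro on a Shared Core

The compounds below may be only part of what the source reports. "The series", "measured", "known", "first", "only" and "open" are said of these compounds alone.

Within the data shown here, compound 1, `Nc1ccccc1NC(=O)c1ccc(CSC(=S)N2CCN(c3ccc(Cl)cc3)CC2)cc1`, is one of three compounds measured in a functional assay on A-375 cells (Homo sapiens) for antiproliferative activity, read by CCK-8 assay, with a stated time of 72 h, tested at 8 uM; on this read-out lower numbers stand for a weaker effect and higher numbers for a stronger effect at the one concentration tested. There compound 1 gives 29%, the lowest of the three numbers. Compound 2, `CC1CCN(C(=S)SCc2ccc(C(=O)Nc3ccccc3N)cc2)CC1`, gives 87.4%, and compound 3, `Nc1ccccc1NC(=O)c1ccc(CSC(=S)N2CCCc3ccccc32)cc1`, gives 81.5%; both stand above compound 1 by margins beyond the scatter, while the difference between them, a number 5.9 percentage points lower from compound 2 to compound 3 (within the scatter), lies within it. Compound 4, `COc1ccc(N2CCN(C(=S)SCc3ccc(C(=O)Nc4ccccc4N)cc3)CC2)cc1`, has not yet been measured. It differs from compound 1 in one place: methoxy in place of chloro on an aromatic carbon.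

Among the measured compounds shown here, only one measured step exists, and it swaps a group on the thiocarbonyl carbon rather than the group that changes here, so it does not bear directly on this change. For the measured compounds named here, the step from compound 1 to compound 4 therefore rests on no measured precedent; the known step, a number 5.9 percentage points lower from compound 2 to compound 3 (within the scatter), only shows that one change elsewhere on the core left the number nearly unchanged. The size and direction of the step in this assay are open. The estimate is placed somewhat above compound 1 with a wide range, since compound 2 with 87.4% and compound 3 with 81.5% show that this core can reach far higher numbers. A rise is expected for compound 4, a number 13 percentage points higher from compound 1 to compound 4 (beyond the scatter). Compound 4 is expected to give 42%, between 15% and 72%.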

Compound 4, a percentage reported as inhibition, at one concentration (the size of the read-out at that concentration, not a potency): 35.9%
The estimate for compound 4 lay 6.1 percentage points above the measured number; low and high end bracket the measured number.
By their numbers in this assay, from the lowest: compounds 1 and 4 (each within the scatter of the next); then compounds 3 and 2 (each within the scatter of the next).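

this assay gives the first reading at this position, where methoxy in place of chloro on an aromatic carbon, para to a large group, gives a number 6.9 percentage points higher from compound 1 to compound 4 (within the scatter). At this one concentration, the 4-chlorophenyl and 4-methoxyphenyl forms of the shared core cannot be told apart, even though the entering group has two heavy atoms and one hydrogen-bond acceptor, and the leaving group has one heavy atom and no hydrogen-bond acceptor. Nothing measured here explains the result or shows what either group does in the cells.

Still open, going by these compounds, is whether a different group on this aromatic carbon, such as an amine, a carboxylic acid or a longer chain like butoxy, would move the number beyond the scatter of compound 1 and compound 4. A single concentration also leaves open whether compound 1 and compound 4 would remain indistinguishable at other concentrations, where a fuller comparison of their effects could be made.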